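Swapping a carbamate for an arylsulfonyl group on compound 2

A few compounds are considered here, and "the series" means these few. Any claim that something is new, unique, unknown or untested is made for them only; others in the source may bear on it.

Compound 1 `O=C(N[C@@H](CCC(=O)N1CCN(c2cccc(NC3=NCCCCN3)c2)CC1)C(=O)O)OCc1ccccc1` gives 1.7 nM
Compound 2 `CCOC(=O)N[C@@H](CCC(=O)N1CCN(c2cccc(NC3=NCCCN3)c2)CC1)C(=O)O` gives 2.1 nM
Compound 3 `CC(C)COC(=O)N[C@@H](CCC(=O)N1CCN(c2cccc(NC3=NCC(O)CN3)c2)CC1)C(=O)O` gives 2 nM

All three values come from a functional assay (muscle tissue) for inhibition, with Homo sapiens as the target (on this read-out lower numbers stand for stronger inhibition and higher numbers for weaker inhibition), and lie within the usual scatter of each other. Compound 2 therefore stands level with the other two, and no order can be read among them.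

Compound 4 `Cc1cc(C)c(S(=O)(=O)N[C@@H](CCC(=O)N2CCN(c3cccc(NC4=NCCCN4)c3)CC2)C(=O)O)c(C)c1` has not been measured yet. It keeps the rest of compound 2 and changes one group, with (2,4,6-trimethylphenyl)sulfonyl in place of ethoxycarbonyl on an amine nitrogen. The incoming group is larger and brings an aromatic ring. Going by the values given here, no measured pair isolates a single change, so the data give no direct size for this one.

The expectation rests on compound 1 (1.7 nM) and compound 3 (2 nM), which stay level with compound 2 (2.1 nM) although their structures differ from it in more than one place. The expected step (a 1.4-fold lower number from compound 2 to compound 4 (0.15 log units; within the scatter)) stays within the scatter, so no clear direction is predicted. In this assay the estimated value for compound 4 is 1.5 nM with an expected range from 0.4 nM to 6 nM (an estimate only).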

Compound 4, half-maximal inhibitory concentration: > 10 nM
Compound 4: a limit, no number (the forecaster's own chance of this, stated with the estimate: 3%); middle value at least 6.6-fold (0.82 log units) away from the limit.
By their numbers in this assay, from the lowest: compounds 1, 3 and 2 (each within the scatter of the next). At a limit, above all of these: compound 4.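

In this assay, the group on this amine nitrogen turns out to matter: (2,4,6-trimethylphenyl)sulfonyl in place of ethoxycarbonyl gives an at least 4.7-fold higher number from compound 2 to compound 4 (0.67 log units; beyond the scatter). For compound 4 the reading > 10 nM is a limit of the assay and not a number, so this step has a lower bound but no exact size: the limit of > 10 nM in this assay, at which 1 of the 4 values shown sits. Compounds 1, 2 and 3 all carry a carbonyl-linked group at this nitrogen, so only compound 4 shows that a different group here can weaken inhibition beyond the scatter.

The compounds shown do not separate the sulfonyl link from the trimethylphenyl ring, since both enter together. A methylsulfonyl or a benzoyl group on this nitrogen would show which of the two parts goes with the weaker inhibition.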